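Replacing dipropylamino on the side chain of compound 2

The source may report more compounds than this note shows. Statements on the series, on what has been measured and on what is new or still open speak of the compounds shown alone.

Measured in a functional assay on MCF7 cells (Homo sapiens) for antiproliferative activity; a lower number here means a stronger inhibitor, a higher number a weaker inhibitor:
Compound 1 `CCN(CC)CCCOc1ccc2cc(NC(=O)c3ccc(O)c(CC=C(C)C)c3)c(=O)oc2c1C`: 6390 nM
Compound 2 `CCCN(CCC)CCCOc1ccc2cc(NC(=O)c3ccc(O)c(CC=C(C)C)c3)c(=O)oc2c1C`: > 50000 nM (a limit)

Compound 2 gives only a limit of this assay and not a number, > 50000 nM, so its place is known from one side only, as the limit of > 50000 nM in this assay, at which 1 of the 2 values shown sits, shows.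

Compound 3 `CC(C)=CCc1cc(C(=O)Nc2cc3ccc(OCCCN(C)C(C)C)c(C)c3oc2=O)ccc1O` carries isopropyl(methyl)amino in place of dipropylamino on a saturated chain carbon, three bonds along the chain from an oxygen on an aromatic ring.

Among the measured compounds shown here, one measured step bears on this place: an at least 7.8-fold higher number from compound 1 to compound 2 (0.89 log units; beyond the scatter), which is beyond the scatter and came with dipropylamino entering in place of diethylamino. With dipropylamino gone, compound 3 is expected to move back towards compound 1, which gives 6390 nM, although that single step is thin support.

A lower number is expected, and the estimated step is an at least 4.1-fold lower number from compound 2 to compound 3 (0.61 log units; beyond the scatter). For compound 3 the estimate is 12000 nM, with an expected range from 3000 nM to 50000 nM.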

Compound 3, half-maximal inhibitory concentration: 1050 nM
Estimate against measurement, compound 3: 11-fold (1.06 log units) above; measured number below the stated range.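

In this assay, isopropyl(methyl)amino on the side chain gives an at least 47-fold lower number from compound 2 to compound 3 (1.67 log units; beyond the scatter), so the loss seen with dipropylamino is more than recovered. It also gives a 6.1-fold lower number from compound 1 to compound 3 (0.78 log units; beyond the scatter), which shows that a change of amine at this position can improve on diethylamino, whereas the earlier pair showed only a loss. Compound 2 stands as a limit and not a number, so the first of these steps is known from one side only: the limit of > 50000 nM in this assay, at which 1 of the 3 values shown sits.

The compounds shown do not separate the effect of branching on the amine from that of the unequal pair of alkyl groups, since isopropyl(methyl)amino differs from diethylamino in both. Dimethylamino, diisopropylamino or a ring amine such as pyrrolidine on the same chain would help show which of these features tracks with the change in antiproliferative activity.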